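This account rests on a few compounds, and the source may have more. Where it says the series, first, only, none or still open, it means among the compounds named here.

In a functional assay on HEK293 cells for agonist activity at G-protein coupled receptor 84 (Homo sapiens), read by calcium flux (on this read-out higher numbers stand for larger maximal responses and lower numbers for smaller maximal responses), compound 1 `CCCCCCc1nc(O)cc(O)n1` gives 99.7%. Compound 2 `CCCCCCCCNc1nc(O)cc(O)n1` gives 91.8% in this assay, a difference that lies within the usual scatter, so neither compound stands apart from the other. Compound 3 `CCCCCCCc1nc(O)cc(O)n1` differs from compound 1 by methyl in place of hydrogen on a saturated chain carbon, six bonds along the chain from an aromatic carbon. For the measured compounds named here, no step between two measured compounds shows what methyl in place of hydrogen does here, so for compound 3 no shift beyond the scatter is expected in this assay. Compound 3 is therefore expected to give 97%, within a range from 82% to 106%, which would amount to an estimated step of a number 2.7 percentage points lower from compound 1 to compound 3 (within the scatter).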

Compound 3, largest response reached (reported as percent of maximum), in percent of the reference or control that the assay uses: 103%
The estimate for compound 3 lay 6 percentage points below the measured number; the range from low to high includes it.
By their numbers in this assay, from the lowest: compounds 2, 1 and 3 (each within the scatter of the next, the first and the last beyond it).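

In this assay, methyl in place of hydrogen on a saturated chain carbon, six bonds along the chain from an aromatic carbon, gives a number 3.3 percentage points higher from compound 1 to compound 3 (within the scatter). For the compounds shown here, this is the first step that can be read at this position, and it shows that the added methyl leaves the maximal response within the scatter. No evidence at hand accounts for this result. From the compounds shown here alone, whether a longer chain at this place would also hold the response remains open. So does the effect of an amine or a carboxylic acid in place of the methyl.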